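This account rests on a few compounds, and the source may have more. Where it says the series, first, only, none or still open, it means among the compounds named here.

Compound 1 `N=C(N)c1ccc(COc2ccc(Cl)cc2)cc1`: 20700000 nM
Compound 2 `N=C(N)c1ccc(COc2ccc(C(=N)N)cc2Cl)cc1`: 3200000 nM

In an ADME assay on L6 cells (Rattus norvegicus) for cytotoxicity, read by resazurin assay, with a stated time of 72 h (on this read-out higher numbers stand for weaker inhibition and lower numbers for stronger inhibition), compound 2 gives 3200000 nM, the lower of the two numbers and clearly apart from compound 1 at 20700000 nM. Compound 3 `N=C(N)c1ccc(COc2ccc(C(=N)N)cc2Br)cc1` keeps the structure of compound 2 except for one swap: bromo in place of chloro on an aromatic carbon. Among the measured compounds shown here, no measured pair shows this swap, so the expectation starts from compound 2 at 3200000 nM and assumes no change beyond the scatter in this assay. The expected step, a 1.1-fold lower number from compound 2 to compound 3 (0.03 log units; within the scatter), is small. For compound 3 the estimate is 3000000 nM, with an expected range of 1200000 nM to 7500000 nM.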

Compound 3, half-maximal inhibitory concentration: 4990000 nM
Compound 3: the middle estimate sits 1.7-fold (0.22 log units) below what was measured; measured number inside the range.
By their numbers in this assay, from the lowest: compounds 2 and 3 (each within the scatter of the next); then compound 1.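

In this assay bromo in place of chloro on this aromatic carbon, ortho to a large group, gives a 1.6-fold higher number from compound 2 to compound 3 (0.19 log units; within the scatter) and so the two halogens cannot be told apart here on this read-out. Among the compounds shown here, this is the first measured view of any change at this position, and it shows that this swap is tolerated without a clear shift. No measurement at hand explains the result. On these data alone, whether a methyl, a methoxy or an amine on the same carbon would also stay within the scatter remains open.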